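Swapping a Fluorinated Benzyl Arm for a Methylpyrrole

The compounds below may be only part of what the source reports. "The series", "measured", "known", "first", "only" and "open" are said of these compounds alone.

Three compounds share a core built from two hydroxyquinoline-bearing arms joined through an amine nitrogen, with a third arm varied. Compound 1 `Oc1ccc(CN(Cc2cccc(C(F)(F)F)c2)Cc2ccc(O)c3ncccc23)c2cccnc12` carries a trifluoromethyl-substituted benzyl arm and gives 2 uM in a functional assay on U-87MG ATCC cells (Homo sapiens) for antiproliferative activity, with a stated time of 3 days; on this read-out lower numbers stand for an effect already at smaller amounts and higher numbers for an effect only at larger amounts of compound. Compound 2 `Oc1ccc(CN(Cc2cc(C(F)(F)F)cc(C(F)(F)F)c2)Cc2ccc(O)c3ncccc23)c2cccnc12` carries two trifluoromethyl groups on that arm. For compound 2 this assay reports only a limit, < 0.2 uM, not a number. The change an at least 10-fold lower number from compound 1 to compound 2 (1.00 log units; beyond the scatter), trifluoromethyl in place of hydrogen on an aromatic carbon, is beyond the scatter. One of the three values shown sits at such a limit (the limit of < 0.2 uM in this assay, at which 1 of the 3 values shown sits).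

Compound 3 `Oc1ccc(CN(Cc2ccc(OC(F)(F)F)cc2)Cc2ccc(O)c3ncccc23)c2cccnc12` carries a 4-(trifluoromethoxy)benzyl arm, and for it this assay has no result: "not determined" (no result reported). Compound 3 therefore has no place among the numbers shown.

Compound 4 `Cn1cccc1CN(Cc1ccc(O)c2ncccc12)Cc1ccc(O)c2ncccc12` differs from compound 3 by 1-methyl-1H-pyrrol-2-yl in place of 4-(trifluoromethoxy)phenyl on a saturated chain carbon bound to an amine nitrogen. Within the data shown here, no measured step covers this change; the only measured step adds a trifluoromethyl group, whereas here an arm bearing fluorine leaves entirely and a smaller 1-methyl-1H-pyrrol-2-yl enters. With compound 1 as the nearest anchor at 2 uM, compound 4 is estimated at 3 uM, with a likely range from 0.7 uM to 12 uM.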

Compound 4, concentration for half-maximal effect: 2 uM
Compound 4: the middle estimate sits 1.5-fold (0.18 log units) above what was measured; the range from low to high includes it.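

Among these compounds, the third arm accepts a much larger swap than the earlier compounds revealed: in this assay there is no change at the digits printed from compound 1 to compound 4 (within the scatter), even though the 3-(trifluoromethyl)phenyl group has left and a 1-methyl-1H-pyrrol-2-yl group sits on the saturated chain carbon bound to the amine nitrogen. Fluorine on this arm and a six-membered ring of carbon only are therefore not needed to reach the level of compound 1, something the earlier step, which only added a trifluoromethyl group, could not show. No measurement shown here bears on why these two different arms give matching values.

Steps to and from compound 3 cannot be read, so the place of the 4-(trifluoromethoxy)benzyl arm in this series stays open. Also open, from the compounds shown here alone, is how this position would respond to a pyrrole ring without its methyl group, or to an arm ending in a carboxylic acid, and whether the shared core would keep its effect with either of them.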